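This account rests on a few compounds, and the source may have more. Where it says the series, first, only, none or still open, it means among the compounds named here.

Measured compounds:
- compound 1 `COC(=O)c1c(Nc2ccc(F)cc2)sc(C(=O)c2ccc(OC)cc2)c1C`: 25.6%
- compound 2 `COC(=O)c1c(Nc2ccc(F)cc2)sc(C(=O)c2ccc(C)cc2)c1C`: "not active" (no number reported)
- compound 3 `COC(=O)c1c(Nc2ccc(Cl)cc2)sc(C(=O)c2ccc(C)cc2)c1C`: "not active" (no number reported)

Of the compounds shown here, three sharing one core have been tested in a functional assay, with a stated time of 150 min, tested at 35 ug/mL; on this read-out higher numbers stand for a stronger effect at the one concentration tested and lower numbers for a weaker effect. Only compound 1 has a number: in this assay compound 1 gives 25.6%. Compound 2 stands without a number; in this assay compound 2 is reported as "not active" (no number reported), and compound 3 is reported in the same way as "not active" (no number reported). So among the three, compound 2 is one of the two entries with no measurable effect, and nothing more can be said about how it ranks against compound 1 beyond that compound 1 shows a number and compound 2 does not.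

The next compound, compound 4 `Cc1ccc(C(=O)c2sc(Nc3ccc(F)cc3)c(C(=O)O)c2C)cc1`, differs from compound 2 in one place: hydrogen in place of methyl on an oxygen next to a carbonyl group. The ester that sits on the core of compound 2 thus becomes a carboxy group in compound 4, and the rest of the molecule is kept.

Among the measured compounds shown here, no measured pair shows what this change does in this assay. Compound 2 gives no number, so the starting point is itself unmeasured in size. The expectation is a small step at most in this assay, with no clear direction, leaving compound 4 near the bottom of the read-out. Compound 4 is therefore estimated to give 10%, expected to fall between 0% and 30%.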

Compound 4, a percentage reported as activity, at one concentration (the size of the read-out at that concentration, not a potency): "not active" (no number reported)
For compound 4 the study gives words and no number; the estimate stays without a comparison.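

Compound 2 and compound 4 are both reported as "not active", with no number, so no step can be read for the change from methoxycarbonyl to carboxy. Nothing shown here bears on this result. The compounds shown leave open what this change does on a compound that gives a measurable effect.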